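This account rests on a few compounds, and the source may have more. Where it says the series, first, only, none or still open, it means among the compounds named here.

The measured compounds:
compound 1, `Cc1cc(CCC#N)cc(C)c1Oc1cc(Nc2ccc(C#N)cc2)c(N)cc1C(F)(F)F`, gives > 7100 nM.
compound 2, `Cc1cc(/C=C/C#N)cc(C)c1Oc1cc(Nc2ccc(C#N)cc2)c(N)cc1C(F)(F)F`, gives 15000 nM.
compound 3, `CC(=O)/C=C/c1cc(C)c(Oc2cc(Nc3ccc(C#N)cc3)c(N)cc2C(F)(F)F)c(C)c1`, gives > 8600 nM.

In an ADME assay on TZM cells (Homo sapiens) for cytotoxicity, read by XTT assay, with a stated time of 4 days (a higher number here means that more compound is tolerated, a lower number that less compound is tolerated), compound 1 stands only at a limit, > 7100 nM, and not at a number. Compound 3 also sits at a limit, > 8600 nM. Only compound 2 gives a number, 15000 nM. Among the compounds with values here, the three steps among them, a step that the limit leaves unreadable from compound 1 to compound 2, a step that the two limits leave unreadable from compound 1 to compound 3 and a step that the limit leaves unreadable from compound 2 to compound 3, are all left unreadable by these limits (the limit of > 7100 nM in this assay, at which 1 of the 3 values shown sits, (the limit of > 8600 nM in this assay, at which 1 of the 3 values shown sits)), so no measured step has a readable size.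

Compound 4, `CNC(=O)c1cc(N)c(Nc2ccc(C#N)cc2)cc1Oc1c(C)cc(CCC#N)cc1C`, differs from compound 1 by methylcarbamoyl in place of trifluoromethyl on an aromatic carbon. Within the data shown here, none of the measured steps touches this group; all three alter the 2-cyanoethyl chain or its cyano group, and none of them is readable. Among the measured compounds shown here, the change to compound 4 therefore has no measured counterpart, and the expectation rests only on where the measured compounds lie. Because compound 1 gives a limit, > 7100 nM, compound 4 is expected to remain in the same weakly cytotoxic region. Because compound 2 gives a number, 15000 nM, a value of this order is taken as the middle. The expected step from compound 1 is thus a step that the limit leaves unreadable from compound 1 to compound 4, no clear direction beyond the scatter. Compound 4 is estimated at 15000 nM, with a range from 6000 nM to 60000 nM.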

Compound 4, half-maximal cytotoxic concentration in the TZM assay: > 9100 nM
Compound 4 was reported as a limit; the forecaster's own chance of this, stated with the estimate: 55%; the middle value lies beyond the limit too.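

In the TZM assay compound 1 and compound 4 both stand at limits, and the step between them cannot be read. In a physicochemical assay for lipophilicity, at pH 7.4 (on this read-out lower numbers stand for lower lipophilicity and higher numbers for higher lipophilicity), compound 1 gives > 5, which is a limit. In the physicochemical assay compound 4 gives 2.65. The compounds shown leave open whether methylcarbamoyl in place of trifluoromethyl shifts the tolerated concentration in the TZM assay at all.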